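A few compounds are considered here, and "the series" means these few. Any claim that something is new, unique, unknown or untested is made for them only; others in the source may bear on it.

Measured compounds:
compound 1, `N#Cc1ccc(/C=C/S(=O)(=O)Cc2ccc(Nc3ncnc4ccccc34)cc2)cc1` — > 100000 nM
compound 2, `O=S(=O)(/C=C/c1ccc(Cl)c(Cl)c1)Cc1ccc(Nc2ncnc3ccccc23)cc1` — 32000 nM

Both were tested in a functional assay on NCI-H520 cells (Homo sapiens); a lower number here means a stronger inhibitor of growth, a higher number a weaker inhibitor of growth. For compound 1 the result is only a limit, > 100000 nM. Compound 2 gives 32000 nM, and the change between them is an at least 3.1-fold lower number from compound 1 to compound 2 (0.49 log units; beyond the scatter), with 3,4-dichlorophenyl in place of 4-cyanophenyl on a double-bonded chain carbon bound to a double-bonded chain carbon. Going by the values given here, compound 2 therefore holds the only actual number here; the other result is the limit of > 100000 nM in this assay, at which 1 of the 2 values shown sits.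

Compound 3, `O=S(=O)(/C=C/c1ccc(Cl)cc1)Cc1ccc(Nc2ncnc3ccccc23)cc1`, differs from compound 2 in one place: hydrogen in place of chloro on an aromatic carbon. Among the compounds with values here, the single measured step, an at least 3.1-fold lower number from compound 1 to compound 2 (0.49 log units; beyond the scatter), concerns the same ring and was at least modest, but it swapped two groups at once, so it gives only a loose guide. Taking away one chloro partly undoes that change, so a weakening of no more than modest size is expected: a 1.7-fold higher number from compound 2 to compound 3 (0.24 log units; within the scatter). Compound 3 is thus estimated at 55000 nM, within 15000 nM to 200000 nM.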

Compound 3, concentration for 50% growth inhibition: 46000 nM
Compound 3: the middle estimate sits 1.2-fold (0.08 log units) above what was measured; low and high end bracket the measured number.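

Going from 3,4-dichlorophenyl to 4-chlorophenyl gives no separation that can be told from the scatter in this assay: a 1.4-fold higher number from compound 2 to compound 3 (0.16 log units; within the scatter). The chloro ortho to the remaining chloro group therefore shows no measurable contribution here, which the earlier pair could not show because it changed both ring groups at once. A single swap on the ring does give a real step, with chloro in place of cyano: an at least 2.1-fold lower number from compound 1 to compound 3 (0.33 log units; beyond the scatter). Compound 1 gives only a limit, so that step has no exact size: the limit of > 100000 nM in this assay, at which 1 of the 3 values shown sits.

Still open, from the compounds shown here alone, is how a plain phenyl ring, or a methoxy or amino group in place of the remaining chloro, would read in this assay. Also open, going by these compounds, is whether a longer chain in place of the double-bonded one would shift the number more than these ring changes do.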